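The source may report more compounds than this note shows. Statements on the series, on what has been measured and on what is new or still open speak of the compounds shown alone.

For the measured compounds named here, compound 2 `O=S(=O)(NCCNc1nccc(-c2c(-c3cccc(F)c3)nc3sccn23)n1)c1ccc(F)cc1` gives the highest of the two numbers so far in a functional assay on A-375 cells (Homo sapiens) for cytotoxicity, read by MTT assay (on this read-out higher numbers stand for weaker inhibition and lower numbers for stronger inhibition), at 9450 nM; its nearest neighbour is compound 1 `O=C(NCCNc1nccc(-c2c(-c3cccc(F)c3)nc3sccn23)n1)c1c(F)cccc1F`, which in this assay gives 2700 nM. Going by the values given here, the only measured step between them, a 3.5-fold higher number from compound 1 to compound 2 (0.54 log units; beyond the scatter), is a modest rise that is beyond the scatter. Compound 3 `O=C(NCCCNc1nccc(-c2c(-c3cccc(F)c3)nc3sccn23)n1)c1ccc(Cl)cc1` is the unmeasured member of the set; it differs from compound 2 by (((4-chlorophenyl)carbonyl)amino)methyl in place of ((4-fluorophenyl)sulfonyl)amino on a saturated chain carbon, two bonds along the chain from a nitrogen on an aromatic ring. This change brings a carbonyl back in place of the sulfonyl, the kind of swap that the step from compound 1 to compound 2 reversed, while also lengthening the chain and exchanging fluorine for chlorine on the aromatic ring. Among the compounds with values here, only that one step bears on the case, so the expectation for compound 3 is a step downward of about the same size, a 2.7-fold lower number from compound 2 to compound 3 (0.43 log units; beyond the scatter), with wide uncertainty because of the added chain carbon and halogen change. Compound 3 is therefore estimated at 3500 nM in this assay, within a range of 1200 nM to 10000 nM.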

Compound 3, half-maximal inhibitory concentration: 13700 nM
Compound 3: middle estimate off by 3.9-fold (0.59 log units), on the low side; the whole stated range lies below it.
By their numbers in this assay, from the lowest: compound 1; then compounds 2 and 3 (each within the scatter of the next).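

In this assay, putting a carbonyl back did not recover the number of compound 1: a 1.4-fold higher number from compound 2 to compound 3 (0.16 log units; within the scatter), so at this place on the saturated chain carbon, (((4-chlorophenyl)carbonyl)amino)methyl and ((4-fluorophenyl)sulfonyl)amino cannot be told apart. The amide link alone therefore does not set the lower number of compound 1, since a 5.1-fold higher number from compound 1 to compound 3 (0.71 log units; beyond the scatter), although both compounds carry a carbonyl there. No evidence is available to explain either step.

From the compounds shown here alone, compound 3 differs from compound 1 by an added methyl and a different aromatic group within one replacement, so the share of each in that step remains open. Also open, going by these compounds, is how a longer chain, or an amine or a carboxylic acid at this place, would read in this assay.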